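The source may hold more compounds than are shown below. What is called first, only, known or untested is meant among the compounds shown, and "the series" means these compounds.

Working notes on the series in a functional assay on MT2 cells (Homo sapiens) for cytotoxicity, read by MTT assay; on this read-out higher numbers stand for lower toxicity in this test and lower numbers for higher toxicity in this test. Three compounds share a core and differ at one aromatic carbon. Compound 1 `CC(C)=CCOc1cc(Nc2nccc(C)n2)ccc1Cl` carries methyl there; in this assay compound 1 gives only a limit of the assay, < 200 nM, and not a number (the limit of < 200 nM in this assay, at which 1 of the 3 values shown sits). Compound 2 `CC(C)=CCOc1cc(Nc2nccc(C(F)(F)F)n2)ccc1Cl` carries trifluoromethyl and gives 2500 nM; compound 3 `COc1ccnc(Nc2ccc(Cl)c(OCC=C(C)C)c2)n1` carries methoxy and gives 9000 nM. Compound 3 therefore stands as the highest of the two numbers that have been read, with compound 2 nearest. The steps are an at least 12-fold higher number from compound 1 to compound 2 (1.09 log units; beyond the scatter), an at least 45-fold higher number from compound 1 to compound 3 (1.65 log units; beyond the scatter) and a 3.6-fold higher number from compound 2 to compound 3 (0.56 log units; beyond the scatter).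

Compound 4 `CC(C)=CCOc1cc(Nc2nccc(CO)n2)ccc1Cl` has not yet been measured in this assay. It differs from compound 3 by hydroxymethyl in place of methoxy on an aromatic carbon. Going by the values given here, no measured step exchanges methoxy for hydroxymethyl, so the nearest guidance is the modest step of a 3.6-fold higher number from compound 2 to compound 3 (0.56 log units; beyond the scatter) and the large step of an at least 45-fold higher number from compound 1 to compound 3 (1.65 log units; beyond the scatter), both of which end at compound 3. Since none of these exchanges bears directly on hydroxymethyl, a step of at most modest size in either direction, or none beyond the scatter, is the expectation: the estimated move is a 1.3-fold lower number from compound 3 to compound 4 (0.11 log units; within the scatter). Compound 4 is accordingly estimated at 7000 nM, within a range from 2500 nM to 20000 nM, pending the measurement.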

Compound 4, half-maximal cytotoxic concentration: 220 nM
Compound 4: middle estimate off by 32-fold (1.50 log units), on the high side, and the stated range ends above it.
By their numbers in this assay, from the lowest: compound 4; then compound 2; then compound 3. At a limit, below all of these: compound 1.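

In this assay, rearranging the same atoms at this position, from methoxy to hydroxymethyl, gives a 41-fold lower number from compound 3 to compound 4 (1.61 log units; beyond the scatter), so this change alone shifts the read-out towards higher toxicity in this test, although the heavy-atom count stays the same and a hydrogen-bond donor enters. Trifluoromethyl gives way to hydroxymethyl with a similarly large move, an 11-fold lower number from compound 2 to compound 4 (1.06 log units; beyond the scatter), which places hydroxymethyl well apart from both groups that had given the higher numbers. Compound 1, with methyl, stands at a limit of the assay and not at a number, so an at least 1.1-fold higher number from compound 1 to compound 4 (0.04 log units; that floor lies within the scatter) has a floor within the scatter and does not separate hydroxymethyl from methyl: the limit of < 200 nM in this assay, at which 1 of the 4 values shown sits.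

The hydrogen-bond donor cannot be tied to the low number from these compounds, as compound 1, with methyl in place of hydroxymethyl, goes against such a link. Open questions are how an aminomethyl group, a carboxylic acid or a longer hydroxyalkyl chain at this position would read in this assay, and whether a value for methyl can be resolved beneath its limit.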